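Butylcarbonyl in place of butylsulfanyl: expected outcome

The source may hold more compounds than are shown below. What is called first, only, known or untested is meant among the compounds shown, and "the series" means these compounds.

compound 1 `CCCC[S+]([O-])c1sc2nc(-c3nccs3)cc(-c3ccc(COC(=O)NCC)cc3)c2c1N`: 3.4 nM
compound 2 `CCCCSc1sc2nc(-c3cccs3)cc(-c3ccccc3)c2c1N`: > 80 nM

In an assay for inhibition of 15-hydroxyprostaglandin dehydrogenase [NAD(+)] (Homo sapiens), read by fluorescence, with a stated time of 15 min, in the presence of a further agent that is not named here (on this read-out higher numbers stand for weaker inhibition and lower numbers for stronger inhibition), compound 1 gives 3.4 nM. For compound 2 only a limit is recorded, > 80 nM, not a number. Compound 2 therefore stands at the limit of > 80 nM in this assay, at which 1 of the 2 values shown sits. Compound 3 `CCCCC(=O)c1sc2nc(-c3cccs3)cc(-c3ccccc3)c2c1N` differs from compound 2 by butylcarbonyl in place of butylsulfanyl on an aromatic carbon. Among the measured compounds shown here, no measured pair matches this change, so the expectation rests on compound 2 alone. The step from compound 2 to compound 3 is expected to be a number no higher from compound 2 to compound 3 (the limit leaves the size open), within the scatter rather than beyond it. Compound 3 is estimated at 80 nM in this assay, with a range from 15 nM to 400 nM.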

Compound 3, half-maximal inhibitory concentration: > 7500 nM
Compound 3: a limit, no number (the forecaster's own chance of this, stated with the estimate: 55%); at least 93-fold (1.97 log units) between middle value and limit.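

Among the compounds shown here, compound 2 and compound 3 are both recorded only as limits, not numbers, so no step between them can be read. The compounds shown leave open whether butylcarbonyl in place of butylsulfanyl changes inhibition at all, and by how much.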